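The source may hold more compounds than are shown below. What is called first, only, known or untested is meant among the compounds shown, and "the series" means these compounds.

Measured so far in a functional assay on the whole organism (strain Wistar) for inhibition, with Rattus norvegicus as the target, read by paw edema, with a stated time of 30 min, at a dose of 10 mg/kg by the intraperitoneal route; a higher number here means more inhibition at the dose given (going by the name of the read-out), a lower number less inhibition:
compound 1, `O=C(N/N=C/c1cccc(Cl)c1)c1cccnc1Nc1cccc(C(F)(F)F)c1`: 77.8%
compound 2, `COc1ccc(/C=N/NC(=O)c2cccnc2Nc2cccc(C(F)(F)F)c2)cc1OC`: 60.1%

Among the measured compounds shown here, compound 2 stands lowest of the numbers measured so far in this assay; its nearest neighbour is compound 1, which lies above it by the step of a number 17.7 percentage points lower from compound 1 to compound 2 (beyond the scatter). That step is the only one in hand, and it concerns a change on the carbon with a double bond to nitrogen, the same place that changes now. Compound 3, `CN(C)c1ccc(/C=N/NC(=O)c2cccnc2Nc2cccc(C(F)(F)F)c2)cc1`, is not yet measured in this assay. It differs from compound 2 as follows: 4-(dimethylamino)phenyl in place of 3,4-dimethoxyphenyl on a carbon with a double bond to nitrogen. Going by these compounds, the measured step, from 3-chlorophenyl to 3,4-dimethoxyphenyl, was modest and downward, but nothing measured shows what 4-(dimethylamino)phenyl does at this place, so the direction remains open and no step beyond the scatter is expected. Compound 3 is accordingly estimated at 58%, range 40% to 76%. The expected step is therefore a number 2.1 percentage points lower from compound 2 to compound 3 (within the scatter).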

Compound 3, a percentage reported as inhibition, in the whole organism at one dose (the size of the read-out at that dose, not a potency): 61.3%
The estimate for compound 3 lay 3.3 percentage points below the measured number, and the stated range covers the measured number.
By their numbers in this assay, from the lowest: compounds 2 and 3 (each within the scatter of the next); then compound 1.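

In this assay, 4-(dimethylamino)phenyl in place of 3,4-dimethoxyphenyl on the carbon with a double bond to nitrogen gives a number 1.2 percentage points higher from compound 2 to compound 3 (within the scatter) and so does not separate these two groups at this position. Set against 3-chlorophenyl, the same group gives a number 16.5 percentage points lower from compound 1 to compound 3 (beyond the scatter) and thus a second step beyond the scatter, so the gap to compound 1 is not confined to 3,4-dimethoxyphenyl. No measurement at hand bears on why compound 1 stands apart from compound 2 and compound 3.

Still open, going by these compounds, is whether a plain phenyl, a phenyl carrying a nitrile or a carboxylic acid on this same carbon would fall with compound 1 or with compound 2 and compound 3. On these data alone, all three compounds share the rest of the core, so it is also open whether this order holds once that core changes.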